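This account rests on a few compounds, and the source may have more. Where it says the series, first, only, none or still open, it means among the compounds named here.

Of the compounds shown here, three sharing one core have been tested in an ADME assay on L929 cells (Mus musculus, culture collection number NCTC 929) for cytotoxicity, read by MTT assay, with a stated time of 72 h; a lower number here means a stronger inhibitor, a higher number a weaker inhibitor. Compound 1, `CCCCCCCCCC(=O)c1c(O)cc(C)oc1=O`, gives 134000 nM. Compound 2, `CCCCCCCCCCCCCCCCc1c(O)cc(C)oc1=O`, gives 38200 nM, the lowest number of the three. Compound 3, `CCCCCCCNC(=O)c1c(O)cc(C)oc1=O`, gives 187000 nM. Compound 2 thus stands apart as the strongest inhibitor here, with its gaps to compound 1 and to compound 3 both beyond the usual scatter. The next compound, compound 4, `CCCCCCCCCCCCCCc1c(O)cc(C)oc1=O`, differs from compound 2 by a single change: hydrogen in place of ethyl on a saturated chain carbon, ten or more bonds along the chain from an aromatic carbon. Among the measured compounds shown here, no measured pair shows the effect of such a change, so the direction is uncertain; a step of modest size, within or just beyond the scatter, toward a higher number is expected for compound 4, as a 1.4-fold higher number from compound 2 to compound 4 (0.13 log units; within the scatter). Compound 4 is estimated to give 52000 nM, between 25000 nM and 110000 nM.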

Compound 4, half-maximal inhibitory concentration: 24100 nM
Beside the measured number, compound 4's estimate is 2.2-fold (0.33 log units) above it; the whole stated range lies above it.
By their numbers in this assay, from the lowest: compounds 4 and 2 (each within the scatter of the next); then compounds 1 and 3 (each within the scatter of the next).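

Among the compounds shown here, this is the first measured pair at this position: hydrogen in place of ethyl, on a saturated chain carbon, gives a 1.6-fold lower number from compound 2 to compound 4 (0.20 log units; within the scatter) and so leaves the two compounds indistinguishable. At this far stretch of the chain, then, the size of this change does not rise above the scatter. Nothing available explains this result.

Still open, going by these compounds, is whether a longer chain, or a much shorter one, would also stay within the scatter. Also open, on these data alone, is what an amine or a carboxylic acid at the chain end would do.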